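Adding a methylpyrazole to compound 3

The source may report more compounds than this note shows. Statements on the series, on what has been measured and on what is new or still open speak of the compounds shown alone.

Compound 3 `c1ccc2c(c1)CCC2c1ncc[nH]1` stands at a limit in a functional assay on CHO cells for agonist activity at Alpha-1D adrenergic receptor (Homo sapiens), read by FLIPR and calcium flux; on this read-out higher numbers stand for an effect only at larger amounts of compound and lower numbers for an effect already at smaller amounts: it gives > 10000 nM, which is a limit of the assay and not a number. Compound 2 `CCS(=O)(=O)Nc1cccc2c1CCC2c1ncc[nH]1` likewise reaches only a limit, > 10000 nM. Compound 1 `c1cc(-c2cn[nH]c2)c2c(c1)C(c1ncc[nH]1)CC2`, which carries a 1H-pyrazol-4-yl group, gives 319 nM. Compound 4 `Cn1ccc(-c2cccc3c2CCC3c2ncc[nH]2)n1` differs from compound 3 by 1-methyl-1H-pyrazol-3-yl in place of hydrogen on an aromatic carbon. The step of an at least 31-fold higher number from compound 1 to compound 3 (1.49 log units; beyond the scatter) shows that losing a pyrazolyl group costs a large amount, so adding one back is expected to lower the number, though the new group is a different isomer and bears a methyl. Compound 4 is therefore expected near 1200 nM, within 250 nM to 8000 nM, an expected at least 8.3-fold lower number from compound 3 to compound 4 (0.92 log units; beyond the scatter).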

Compound 4, half-maximal effective concentration: > 10000 nM
Compound 4: only a limit was reported (the forecaster's own chance of this, stated with the estimate: 30%); at least 8.3-fold (0.92 log units) between middle value and limit.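

In this assay, 1-methyl-1H-pyrazol-3-yl in place of 1H-pyrazol-4-yl gives an at least 31-fold higher number from compound 1 to compound 4 (1.49 log units; beyond the scatter) and so, on this aromatic carbon, the presence of a pyrazole alone does not preserve the effect seen with compound 1. The steps from compound 2 and compound 3 to compound 4 cannot be read: the limit of > 10000 nM in this assay, at which 3 of the 4 values shown sit.

The compounds shown leave open whether the methyl or the point of attachment accounts for the step, which 1-methyl-1H-pyrazol-4-yl or 1H-pyrazol-3-yl on the same carbon would separate. As far as these compounds go, how an amine or a carboxylic acid would behave there also remains open.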